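Nitrophenyl sulfonate shuffle on a thiadiazole amide

The compounds below may be only part of what the source reports. "The series", "measured", "known", "first", "only" and "open" are said of these compounds alone.

Compound 1 `N#C/C(=C\c1ccccc1OS(=O)(=O)c1ccc([N+](=O)[O-])cc1)C(=O)Nc1nnc(Cc2cccc3ccccc23)s1` gives 18% in a functional assay on HL-60 cells (Homo sapiens) for inhibition, read by CCK-8 assay, with a stated time of 48 h, tested at 20 uM; a lower number here means less inhibition of growth, a higher number more inhibition of growth at the concentration tested. Compound 2 `N#C/C(=C\c1ccccc1OS(=O)(=O)c1ccccc1[N+](=O)[O-])C(=O)Nc1nnc(Cc2cccc3ccccc23)s1` gives 23% in this assay; the change is 2-nitrophenyl in place of 4-nitrophenyl on a sulfonyl sulfur, and it makes a number 5 percentage points higher from compound 1 to compound 2 (within the scatter). Compound 3 `N#C/C(=C\c1ccccc1OS(=O)(=O)c1ccc([N+](=O)[O-])cc1)C(=O)Nc1nnc(Cc2ccc(Cl)cc2)s1` gives 34% in this assay; its core differs from that of compound 1 by 4-chlorophenyl in place of naphthalen-1-yl on a saturated chain carbon bound to an aromatic carbon, and this makes a number 16 percentage points higher from compound 1 to compound 3 (beyond the scatter). Compound 4 `N#C/C(=C\c1ccccc1OS(=O)(=O)c1ccccc1[N+](=O)[O-])C(=O)Nc1nnc(Cc2ccc(Cl)cc2)s1` is not yet measured in this assay. It differs from compound 3 by 2-nitrophenyl in place of 4-nitrophenyl on a sulfonyl sulfur, the same change as from compound 1 to compound 2, made at the same place. The step from compound 3 to compound 4 in this assay is therefore expected to be small, a number 5 percentage points higher from compound 3 to compound 4 (within the scatter), because it is the same change as a number 5 percentage points higher from compound 1 to compound 2 (within the scatter). Compound 4 is expected to give about 39% in this assay, between 25% and 52%.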

Compound 4, percent growth inhibition at one concentration: 19%
For compound 4 the middle estimate is 20 percentage points above the measured one, and the stated range ends above it.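

In this assay, 2-nitrophenyl in place of 4-nitrophenyl on the sulfonyl sulfur gives a number 15 percentage points lower from compound 3 to compound 4 (beyond the scatter), so this change did not carry from the core of compound 1 to the core of compound 3: the same change on two cores in this assay, a number 5 percentage points higher (within the scatter) from compound 1 to compound 2 and a number 15 percentage points lower (beyond the scatter) from compound 3 to compound 4, 20 percentage points apart, beyond the scatter of two such steps

Read the other way, 4-chlorophenyl in place of naphthalen-1-yl gives a number 4 percentage points lower from compound 2 to compound 4 (within the scatter), so the effect of that change also depends on the partner group: the same change on two cores in this assay, a number 16 percentage points higher (beyond the scatter) from compound 1 to compound 3 and a number 4 percentage points lower (within the scatter) from compound 2 to compound 4, 20 percentage points apart, beyond the scatter of two such steps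

The two changes therefore do not add up across these four compounds, but the result does not show why, nor does it give a rule for any other core.

The compounds shown leave open how the nitrophenyl swap would read with a plain phenyl or a 4-methoxyphenyl in place of the 4-chlorophenyl.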